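Para-chloro on the amidine phenyl: cytotoxicity expectation

The source may report more compounds than this note shows. Statements on the series, on what has been measured and on what is new or still open speak of the compounds shown alone.

Measured compounds:
compound 1 `CC(C)CCc1sc(NC(=O)c2cc(NC(=O)c3cc(NC(=N)c4cccc(F)c4)cn3C)cn2C)nc1C(=O)NCCCN(C)C` — 18 ug/mL
compound 2 `CC(C)CCc1sc(NC(=O)c2cc(NC(=O)c3cc(NC(=N)c4ccc(F)cc4)cn3C)cn2C)nc1C(=O)NCCCN(C)C` — 18 ug/mL
compound 3 `CC(C)CCc1sc(NC(=O)c2cc(NC(=O)c3cc(NC(=N)c4ccccc4)cn3C)cn2C)nc1C(=O)NCCCN(C)C` — > 32 ug/mL

All three share one core and differ only in the phenyl attached to the amidine carbon. In an ADME assay on HEK293 cells (Homo sapiens) for cytotoxicity, read by fluorescence and resazurin assay, with a stated time of 20 h (on this read-out higher numbers stand for lower toxicity in this test and lower numbers for higher toxicity in this test), compound 1 and compound 2 give the same reading: no change at the digits printed from compound 1 to compound 2 (within the scatter). Compound 3 carries no substituent on that phenyl, and its reading is a limit of the assay, not a number; this is the limit of > 32 ug/mL in this assay, at which 1 of the 3 values shown sits. Against that limit, an at least 1.7-fold higher number from compound 1 to compound 3 (0.24 log units; that floor lies within the scatter) and an at least 1.7-fold higher number from compound 2 to compound 3 (0.24 log units; that floor lies within the scatter).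

Compound 4 `CC(C)CCc1sc(NC(=O)c2cc(NC(=O)c3cc(NC(=N)c4ccc(Cl)cc4)cn3C)cn2C)nc1C(=O)NCCCN(C)C` is the next step from compound 3: chloro in place of hydrogen on an aromatic carbon. The step that bears most directly on it is the reverse of the move from compound 2 to compound 3, where a para halogen left the ring and the reading rose only to a limit whose floor lies within the scatter. Putting a halogen back at the same place is therefore expected to give, in this assay, a step of an at least 2.0-fold lower number from compound 3 to compound 4 (0.30 log units; that floor lies within the scatter), either no change beyond the scatter or a somewhat lower number. Compound 4 is estimated at 16 ug/mL, within 6 ug/mL to 40 ug/mL.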

Compound 4, half-maximal cytotoxic concentration: 10 ug/mL
Beside the measured number, compound 4's estimate is 1.6-fold (0.20 log units) above it, and the stated range covers the measured number.
By their numbers in this assay, from the lowest: compounds 4, 1 and 2 (each within the scatter of the next). At a limit, above all of these: compound 3.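

Phenyl to 4-chlorophenyl gives the first step at this position that clears the scatter, with an at least 3.2-fold lower number from compound 3 to compound 4 (0.50 log units; beyond the scatter), so a substituent at this place on the ring can lower the number in this assay. Chloro and fluoro at this place cannot be told apart, with a 1.8-fold lower number from compound 2 to compound 4 (0.26 log units; within the scatter), and the 3-fluorophenyl compound gives the same picture, with a 1.8-fold lower number from compound 1 to compound 4 (0.26 log units; within the scatter). The reading of compound 3 is a limit of the assay and not a number, so the step from it is only a floor: the limit of > 32 ug/mL in this assay, at which 1 of the 4 values shown sits.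

The compounds shown leave open whether only halogens do this, or whether a methyl or methoxy group at the same place would also lower the number. They also leave open whether a bromo group would continue the same trend or whether 3-chlorophenyl would read like 4-chlorophenyl.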